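A few compounds are considered here, and "the series" means these few. Any claim that something is new, unique, unknown or untested is made for them only; others in the source may bear on it.

In an assay on microsomes from intestine for inhibition of acyl-CoA:cholesterol acyltransferase (Oryctolagus cuniculus) (on this read-out lower numbers stand for stronger inhibition and higher numbers for weaker inhibition), compound 1 `CC(C)c1cccc(C(C)C)c1OC(=O)NC(=O)OCc1ccccc1` gives 77 nM. Compound 2 `CCCCCCCCCCCOC(=O)NC(=O)Oc1c(C(C)C)cccc1C(C)C` gives 140 nM in this assay; of the two numbers shown it sits alongside compound 1, the step of a 1.8-fold higher number from compound 1 to compound 2 (0.26 log units; within the scatter) being within the scatter. Compound 3 `CCCCCCCCCCCCCCCCOC(=O)NC(=O)Oc1c(C(C)C)cccc1C(C)C` has not been measured in this assay. It differs from compound 2 by pentyl in place of hydrogen on a saturated chain carbon, ten or more bonds along the chain from an oxygen next to a carbonyl group. Within the data shown here, the only measured step that bears on it, a 1.8-fold higher number from compound 1 to compound 2 (0.26 log units; within the scatter), also altered this chain and stayed within the scatter, so no step beyond the scatter is expected here. Compound 3 is therefore estimated at 160 nM, with a range from 55 nM to 480 nM. The expected step is a 1.1-fold higher number from compound 2 to compound 3 (0.06 log units; within the scatter).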

Compound 3, half-maximal inhibitory concentration: 50 nM
Compound 3: the middle estimate sits 3.2-fold (0.51 log units) above what was measured; the whole stated range lies above it.
By their numbers in this assay, from the lowest: compounds 3, 1 and 2 (each within the scatter of the next, the first and the last beyond it).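

With pentyl in place of hydrogen on a saturated chain carbon, ten or more bonds along the chain from an oxygen next to a carbonyl group, this assay shows a 2.8-fold lower number from compound 2 to compound 3 (0.45 log units; beyond the scatter) as a modest step. This position therefore responds to added chain length, which a 1.8-fold higher number from compound 1 to compound 2 (0.26 log units; within the scatter) could not show, since that step stayed within the scatter and replaced phenyl with decyl. No measurement shown accounts for the step. From the compounds shown here alone, whether a longer chain would lower the number further stays open, as does the effect of an amine or a carboxylic acid on this chain.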